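A few compounds are considered here, and "the series" means these few. Any claim that something is new, unique, unknown or untested is made for them only; others in the source may bear on it.

Measured so far:
compound 1 `CC(C)c1nc2c(OCc3ccccc3)cccn2c1N` gives 0%
compound 2 `CC(C)(C)c1nc2c(OCc3ccccc3)cccn2c1N` gives 0%
compound 3 `CCNc1c(C)nc2c(OCc3ccccc3)cccn12` gives 68%

All three were tested in a functional assay on the whole organism with Canis familiaris (Canis lupus familiaris) as the target, at a dose of 8 mg/kg by the oral route; on this read-out lower numbers stand for a weaker effect and higher numbers for a stronger effect at the one dose given. Compound 1 and compound 2 share a core and differ by methyl in place of hydrogen on a saturated chain carbon bound to an aromatic carbon and two saturated chain carbons; this gave no change at the digits printed from compound 1 to compound 2 (within the scatter). Compound 3 is built from the same atoms as compound 1 but joined differently, and the difference between the two cores is not broken down here; what the numbers show is that compound 3 reaches 68% where compound 1 stays at 0%.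

Compound 4 `CCCNc1c(C)nc2c(OCc3ccccc3)cccn12` is the next one to be tested. It differs from compound 3 by methyl in place of hydrogen on a saturated chain carbon, two bonds along the chain from a nitrogen on an aromatic ring. Within the data shown here, this is the same kind of change as the one from compound 1 to compound 2, but not the same: there the added methyl sat on a saturated chain carbon bound to an aromatic carbon and two saturated chain carbons, here it sits on a saturated chain carbon, two bonds along the chain from a nitrogen on an aromatic ring. The earlier step started from a compound with no measurable effect, so it says little about what such a step does on an active compound. Compound 4 is therefore expected to give a number 8 percentage points lower from compound 3 to compound 4 (within the scatter) in this assay, a modest step that may lie within the scatter, resting on the small earlier step of no change at the digits printed from compound 1 to compound 2 (within the scatter) and on the value of compound 3 68%. The estimate for compound 4 is 60%, between 30% and 85%.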

Compound 4, a percentage reported as inhibition, in the whole organism at one dose (the size of the read-out at that dose, not a potency): 68%
Estimate against measurement, compound 4: 8 percentage points below; measured number inside the range.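

In this assay, putting methyl in place of hydrogen on a saturated chain carbon, two bonds along the chain from a nitrogen on an aromatic ring, turns ethylamino into propylamino and gives no change at the digits printed from compound 3 to compound 4 (within the scatter). Set beside the earlier methyl step on the other core, the result is the same: the same change on two cores in this assay, no change at the digits printed (within the scatter) from compound 1 to compound 2 and no change at the digits printed (within the scatter) from compound 3 to compound 4, 0 percentage points apart, within the scatter of two such steps

This agreement shows only that neither of these two methyl additions moved the read-out, and it does not show that the change carries over from one core to another, since the methyl sits at a different place on each core and the earlier pair has no effect to lose, with compound 1 at 0% and compound 2 at 0%, while compound 3 gives 68%. The compounds shown leave open how far the chain can grow on the active core, for example what butylamino would give in place of propylamino. They also leave open what a chain ending in a carboxylic acid would do there in this assay.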